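Pyridinyl for naphthalenyl on a spiro thiophene series

The source may report more compounds than this note shows. Statements on the series, on what has been measured and on what is new or still open speak of the compounds shown alone.

Measured so far:
compound 1 `COC1Cc2c(csc2-c2cccc3ccccc23)C2(CCN(Cc3ccccc3)CC2)O1`, 5 nM
compound 2 `COC1Cc2c(csc2-c2cccnc2)C2(CCN(Cc3ccccc3)CC2)O1`, 2.2 nM
compound 3 `COC1Cc2cc(-c3cccc4ccccc34)sc2C2(CCN(Cc3ccccc3)CC2)O1`, 12 nM

All three were run in an assay on membranes from brain for displacement of a labelled ligand from Sigma non-opioid intracellular receptor 1 (Cavia porcellus), read by scintillation counting, with a stated time of 120 min; on this read-out lower numbers stand for stronger inhibition and higher numbers for weaker inhibition. Compound 1 and compound 3 are built from the same atoms joined differently; the difference between the two cores is not broken down here. Compound 3 gives the highest number of the three. From compound 1 to compound 2 the change is pyridin-3-yl in place of naphthalen-1-yl on an aromatic carbon and gives a 2.3-fold lower number from compound 1 to compound 2 (0.36 log units; beyond the scatter). The unmeasured compound 4 `COC1Cc2cc(-c3cccnc3)sc2C2(CCN(Cc3ccccc3)CC2)O1` carries the same kind of change on the core of compound 3: pyridin-3-yl in place of naphthalen-1-yl on an aromatic carbon. The place differs in wording: in compound 1 the carbon is next to the ring atom that bears a fused ring, in compound 3 it is two ring bonds from two ring atoms that each bear a fused ring. Among the measured compounds shown here, because a 2.3-fold lower number from compound 1 to compound 2 (0.36 log units; beyond the scatter) is the only step of this kind seen, compound 4 is expected to show a similar step, a 2.4-fold lower number from compound 3 to compound 4 (0.38 log units; beyond the scatter), from compound 3. Compound 4 is thus estimated at 5 nM, between 2 nM and 13 nM.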

Compound 4, inhibition constant: 2.5 nM
The estimate for compound 4 lay 2.0-fold (0.30 log units) above the measured number, and the stated range covers the measured number.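

In this assay, pyridin-3-yl in place of naphthalen-1-yl on the core of compound 3 gives a 4.8-fold lower number from compound 3 to compound 4 (0.68 log units; beyond the scatter). The steps on the two cores do not differ beyond the usual scatter: the same change on two cores in this assay, a 2.3-fold lower number (0.36 log units; beyond the scatter) from compound 1 to compound 2 and a 4.8-fold lower number (0.68 log units; beyond the scatter) from compound 3 to compound 4, 2.1-fold (0.32 log units) apart, within the scatter of two such steps. The change therefore carries over between these two cores in direction and, within the scatter, in size, but two cores are too few to show that it holds across the series, and the numbers do not show what drives the step.

Going by these compounds, whether a phenyl, a pyridin-4-yl or an aminomethyl group on the same aromatic carbon would give a similar step remains open. Also open, on these data alone, is whether the step would persist on a third core.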